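Shortening the acyl chain on a fused piperazine quinazoline

The compounds below may be only part of what the source reports. "The series", "measured", "known", "first", "only" and "open" are said of these compounds alone.

Two compounds share a fused piperazine core and a dimethoxy-substituted bicyclic amine. Compound 1 `CCCN(CCC)c1nc(N2CCN(C(=O)c3ccco3)[C@@H]3CCCC[C@@H]32)nc2cc(OC)c(OC)cc12` carries a dipropylamino group and a furoyl amide; in an assay on CHO cells for displacement of a labelled ligand from Alpha-1B adrenergic receptor (Homo sapiens), with a stated time of 30 min (a higher number here means a weaker inhibitor, a lower number a stronger inhibitor), compound 1 gives 0.129 nM. Compound 2 `CCCCCC(=O)N1CCN(c2nc(N)c3cc(OC)c(OC)cc3n2)[C@@H]2CCCC[C@@H]21` carries a primary amine and a hexanoyl amide; in this assay compound 2 gives 0.912 nM, the higher of the two numbers, with compound 1 sitting well apart at the lower end. Compound 3 `COc1cc2nc(N3CCN(C(C)=O)[C@H]4CCCC[C@H]43)nc(N)c2cc1OC` is not yet measured. It differs from compound 2 by hydrogen in place of butyl on a saturated chain carbon bound to a carbonyl carbon, so the pentylcarbonyl becomes an acetyl. Within the data shown here, with no measured pair showing this change, the expectation is a modest rise in the number for compound 3, a step of a 2.2-fold higher number from compound 2 to compound 3 (0.34 log units; beyond the scatter) in this assay, but the direction is uncertain. Compound 3 is estimated at 2 nM, within a range from 0.4 nM to 10 nM.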

Compound 3, inhibition constant: 9.12 nM
Compound 3: the middle estimate sits 4.6-fold (0.66 log units) below what was measured; the range from low to high includes it.
By their numbers in this assay, from the lowest: compound 1; then compound 2; then compound 3.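

Among these compounds, the change from pentylcarbonyl to acetyl gives the only measured step at this position: in this assay, removing the butyl from the saturated chain carbon bound to a carbonyl carbon brings a 10-fold higher number from compound 2 to compound 3 (1.00 log units; beyond the scatter) on the same amine-bearing core. This shows that the position is not indifferent to the chain it carries, as the acetyl compound is clearly the weaker inhibitor of this pair. Nothing available accounts for the size of this step or explains how the butyl contributes to it.

With only the pentylcarbonyl and acetyl forms to compare, the compounds shown leave open whether the number changes gradually with chain length or mainly over one part of that range. They also leave open how a propyl group, a longer chain or a terminal amine at this place would read in this assay on this core.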